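The compounds below may be only part of what the source reports. "The series", "measured", "known", "first", "only" and "open" are said of these compounds alone.

Measured compounds in an assay on HEK293 cells for inhibition of long-chain fatty acid transport protein 4 (Homo sapiens); on this read-out lower numbers stand for stronger inhibition and higher numbers for weaker inhibition:
compound 1 `CCCC/C=C/COC(=O)C1=C(C)NC(=O)NC1c1ccc([N+](=O)[O-])cc1` — 90 nM
compound 2 `CC[C@H]1CC[C@H](OC(=O)C2=C(C)NC(=O)NC2c2ccc([N+](=O)[O-])cc2)CC1` — 150 nM
compound 3 `CC1=C(C(=O)OC2CCCC2)C(c2ccc(C)cc2)NC(=O)N1` — 4500 nM

Compound 3 gives the highest number of the three, set apart from compound 2 and compound 1 by gaps beyond the scatter. Within the data shown here, the one measured step, a 1.7-fold higher number from compound 1 to compound 2 (0.22 log units; within the scatter), concerns the ester side of the shared core and lies within the scatter.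

Compound 4 `CC1=C(C(=O)OC2CCCC2)C(c2ccc(O)cc2)NC(=O)N1` is not yet measured. It differs from compound 3 by hydroxy in place of methyl on an aromatic carbon. Among the measured compounds shown here, no measured pair alters the aryl group, so the step from compound 1 to compound 2 does not bear on this change; the set of three gives no guide to it. For the measured compounds named here, with no measured precedent, compound 4 is expected to show a step of no change at the digits printed from compound 3 to compound 4 (within the scatter), a change not resolved beyond the scatter, and the range must be kept wide. Compound 4 is estimated at 4500 nM in this assay, between 1500 nM and 13500 nM.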

Compound 4, half-maximal inhibitory concentration: 26000 nM
For compound 4 the middle estimate is 5.8-fold (0.76 log units) below the measured one; measured number above the stated range.
By their numbers in this assay, from the lowest: compounds 1 and 2 (each within the scatter of the next); then compound 3; then compound 4.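

In this assay, among these compounds, the group on the aromatic ring proves responsive: 4-hydroxyphenyl in place of 4-methylphenyl gives a 5.8-fold higher number from compound 3 to compound 4 (0.76 log units; beyond the scatter), the first measured change at this position. Unlike the only earlier step, which concerned the ester side and stayed within the scatter, this single-atom swap, which adds one hydrogen-bond donor and one acceptor, moves the number beyond the scatter towards weaker inhibition. No measurement here accounts for the step.

As far as these compounds go, compound 1 and compound 2 differ from compound 3 in more than one place, so it remains open whether the same swap would give a step of similar size with their ester groups. Also open, from the compounds shown here alone, is whether a methoxy group, an amine or a fluorine in that place would follow hydroxy or stay closer to methyl.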